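Cytotoxicity notes on a benzimidazole-linked benzimidazolone pair

The source may hold more compounds than are shown below. What is called first, only, known or untested is meant among the compounds shown, and "the series" means these compounds.

Measured so far:
compound 1, `C=C(C)n1c(=O)n(Cc2nc3ccccc3n2CCC(C)C)c2ccccc21`: 24600 nM
compound 2, `CC(C)CCn1c(Cn2c(=O)n(C(C)C)c3ccccc32)nc2cc(CN(C)C)ccc21`: 5650 nM

In an ADME assay on HEp-2 cells (Homo sapiens) for cytotoxicity (on this read-out higher numbers stand for lower toxicity in this test and lower numbers for higher toxicity in this test), compound 1 gives 24600 nM and compound 2 gives 5650 nM. Compound 2 stands lowest of the two numbers; its nearest neighbour is compound 1, and that gap lies beyond the scatter. The two differ in more than one place, so no single change can be read from them.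

Compound 3, `CC(C)CCn1c(Cn2c(=O)n(C(C)C)c3ccccc32)nc2cc(C(C)(C)N)ccc21`, is not yet measured in this assay. It differs from compound 2 as follows: 1-amino-1-methylethyl in place of (dimethylamino)methyl on an aromatic carbon

Going by the values given here, no measured pair isolates this change, so the size of the step is open. Compound 3 is expected to land close to compound 2, with the step from compound 2 to compound 3 expected to be a 1.2-fold higher number from compound 2 to compound 3 (0.09 log units; within the scatter), not clearly beyond the scatter in either direction. Compound 3 is estimated at 7000 nM, within 2500 nM to 20000 nM.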

Compound 3, half-maximal cytotoxic concentration: 3270 nM
The estimate for compound 3 lay 2.1-fold (0.33 log units) above the measured number; measured number inside the range.
By their numbers in this assay, from the lowest: compounds 3 and 2 (each within the scatter of the next); then compound 1.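

Trading (dimethylamino)methyl for 1-amino-1-methylethyl on this aromatic carbon gives the first single-place step in the series, a 1.7-fold lower number from compound 2 to compound 3 (0.24 log units; within the scatter) in this assay and so no shift past the scatter. The same atoms joined differently, with a hydrogen-bond donor in the entering group that the leaving group lacks, leave compound 2 and compound 3 indistinguishable in this test. Nothing at hand accounts for this outcome.

Going by these compounds, whether this position responds to other groups stays open: a carboxylic acid or a plain hydrogen on the same aromatic carbon would show whether the read-out depends on an amine here at all. Steps from compound 1 to compound 2 or compound 3 cannot be read, as those compounds differ in more than one place.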